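The source may report more compounds than this note shows. Statements on the series, on what has been measured and on what is new or still open speak of the compounds shown alone.

Measured compounds:
Compound 1 `CCCCn1c(-c2ccccc2)c(C)[nH]c1=O` — > 100000 nM
Compound 2 `Cc1[nH]c(=O)n(C)c1-c1ccc(OC(C)C)cc1` — 20400 nM
Compound 3 `CCCCCCCCCCc1ccc(-c2c(C)[nH]c(=O)n2C)cc1` — 7900 nM

In a functional assay on brain (Rattus norvegicus, strain Wistar) for inhibition (on this read-out higher numbers stand for weaker inhibition and lower numbers for stronger inhibition), compound 1 gives > 100000 nM, which is a limit of the assay and not a number. That entry is the limit of > 100000 nM in this assay, at which 1 of the 3 values shown sits. Among the two actual numbers, compound 2 stands highest with 20400 nM. Its nearest neighbour, compound 3, gives 7900 nM, a gap that lies beyond the usual scatter, so compound 3 is the stronger inhibitor of the two.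

Compound 4 `Cc1[nH]c(=O)n(C)c1-c1ccc(Oc2ccccc2)cc1` is not yet measured. It differs from compound 2 in one place: phenyl in place of isopropyl on an oxygen on an aromatic ring. Going by the values given here, no measured pair shows this same change, so the expectation rests only on the fact that compound 3, bearing a longer substituent on the ring, sits at a lower number than compound 2. The expected step is a 2.0-fold lower number from compound 2 to compound 4 (0.31 log units; beyond the scatter), a modest move toward stronger inhibition in this assay that may well stay inside the scatter. Compound 4 is estimated at 10000 nM, with a likely range from 3000 nM to 40000 nM.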

Compound 4, half-maximal inhibitory concentration: 8100 nM
Compound 4: middle estimate off by 1.2-fold (0.09 log units), on the high side, and the stated range covers the measured number.
By their numbers in this assay, from the lowest: compounds 3 and 4 (each within the scatter of the next); then compound 2. At a limit, above all of these: compound 1.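

In this assay, going by these compounds alone, the step from isopropoxy to phenoxy is the first that can be read at this position: phenyl in place of isopropyl on the oxygen gives a 2.5-fold lower number from compound 2 to compound 4 (0.40 log units; beyond the scatter). The step is modest, but it shows that this oxygen can carry an aromatic ring instead of a branched alkyl group without any loss of inhibition. Nothing measured here accounts for the step.

The compounds shown leave open whether the aromatic ring itself matters or simply the larger group, and a cyclohexyl group on the same oxygen would tell these two apart. From the compounds shown here alone, it also remains open how inhibition responds when the new phenyl ring carries a further group, such as a methoxy group or an amine.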